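The source may hold more compounds than are shown below. What is called first, only, known or untested is meant among the compounds shown, and "the series" means these compounds.

Measured so far in an ADME assay on the whole organism (Macaca fascicularis) for pharmacokinetics, read by LC-MS, using cassette dosing, at a dose of 1 mg/kg by the oral route; on this read-out lower numbers stand for lower exposure and higher numbers for higher exposure at the dose given:
- compound 1 `CCCCN(c1nc2c(C(=O)O)cccc2o1)[C@H](C)c1ccc(-c2ccccc2-c2nnn[nH]2)cc1`: 238 nM
- compound 2 `CCCCN(c1nc2c(C(=O)O)cccc2o1)[C@H](C)c1ccc(-c2cc(Cl)ccc2-c2nc(=O)o[nH]2)cc1`: 677 nM

Within the data shown here, compound 1 stands at the lower of the two numbers known in this assay; compound 2 sits above it, beyond the scatter. Among the measured compounds shown here, no single-point step between compound 1 and compound 2 is available, as they differ in more than one place, so only their two values are on record.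

Compound 3 `CCCCN(c1nc2c(C(=O)NS(C)(=O)=O)cccc2o1)[C@H](C)c1ccc(-c2ccccc2-c2nnn[nH]2)cc1` is not yet measured. It differs from compound 1 in one place: methanesulfonamido in place of hydroxy on a carbonyl carbon — methanesulfonamido in place of hydroxy on a carbonyl carbon, or, read one bond further out, carboxy to (methylsulfonyl)carbamoyl.

For the measured compounds named here, no measured step of this kind exists, so the expectation rests on the spread seen between compound 1 and compound 2 alone. A step from compound 1 to compound 3 of about a 1.2-fold lower number from compound 1 to compound 3 (0.08 log units; within the scatter) is expected, with no firm direction and possibly within the scatter. Compound 3 is estimated at 200 nM, within a range of 50 nM to 800 nM.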

Compound 3, maximal plasma concentration: 40.4 nM
Compound 3: middle estimate off by 5.0-fold (0.69 log units), on the high side; measured number outside the range, below it.
By their numbers in this assay, from the lowest: compound 3; then compound 1; then compound 2.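

In this assay, among these compounds, methanesulfonamido in place of hydroxy on a carbonyl carbon gives a 5.9-fold lower number from compound 1 to compound 3 (0.77 log units; beyond the scatter) and provides the first single-place comparison. The exposure read-out therefore responds to this one change at this position, which the gap between compound 1 and compound 2, spread over more than one place, could not show. At this dose, (methylsulfonyl)carbamoyl does not match carboxy on the core of compound 1.

As far as these compounds go, it remains open whether an amino group on the same carbonyl carbon, giving a primary amide, or benzenesulfonamido would also give a lower number than carboxy. From the compounds shown here alone, it is also open whether methanesulfonamido has the same effect on compound 2. No measurement on hand explains the drop.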